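This account rests on a few compounds, and the source may have more. Where it says the series, first, only, none or still open, it means among the compounds named here.

Within the data shown here, compound 1 `O=c1ccc(-c2ccc3cn[nH]c3c2)cn1Cc1cccc(Cl)c1` is one of two compounds measured in an ADME assay on microsomes (Mus musculus) for metabolic stability, read by LC-MS, using NADPH, with a stated time of 1 h, tested at 1 uM (on this read-out higher numbers stand for a more stable compound and lower numbers for a less stable compound), where compound 1 gives 39%. Compound 2 `CC(=O)Nc1cccc(Cn2cc(-c3ccc4cn[nH]c4c3)ccc2=O)c1`, which carries an acetamido in place of the chloro on an aromatic carbon, gives 43% in this assay; the step of a number 4 percentage points higher from compound 1 to compound 2 (within the scatter) stays within the scatter, so the two numbers do not stand apart from each other. Compound 3 `O=c1ccc(-c2ccc3cn[nH]c3c2)cn1Cc1ccccc1F` has not yet been measured in this assay. It differs from compound 1 in one place: 2-fluorophenyl in place of 3-chlorophenyl on a saturated chain carbon bound to an aromatic nitrogen. Among the measured compounds shown here, no measured step exchanges one halogen-bearing group for another, so the only step available for comparison is the one between compound 1 and compound 2, and it was within the scatter. On that basis compound 3 is expected to show a step of a number 1 percentage points higher from compound 1 to compound 3 (within the scatter) that remains within the scatter. The estimate for compound 3 is 40%, with a range from 25% to 55%.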

Compound 3, percent of the compound remaining: 1.2%
For compound 3 the middle estimate is 38.8 percentage points above the measured one; measured number outside the range, below it.
By their numbers in this assay, from the lowest: compound 3; then compounds 1 and 2 (each within the scatter of the next).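

At this position, on a saturated chain carbon bound to an aromatic nitrogen, the earlier exchange of chloro for acetamido had given only a number 4 percentage points higher from compound 1 to compound 2 (within the scatter) in this assay, so the ring substituent could have seemed to matter little. Placing 2-fluorophenyl in place of 3-chlorophenyl instead gives a number 37.8 percentage points lower from compound 1 to compound 3 (beyond the scatter), which shows that the number on this read-out can depend strongly on the aryl group held at this position, even though the two groups match in every count of heavy atoms, donors and acceptors. Nothing available explains why the number falls so far.

The compounds shown leave open whether the fall goes with the fluorine or with its place, as neither 3-fluorophenyl nor 2-chlorophenyl stands among them. They also leave open how an unsubstituted phenyl or a 2-methoxyphenyl would read at this position.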